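A few compounds are considered here, and "the series" means these few. Any claim that something is new, unique, unknown or untested is made for them only; others in the source may bear on it.

Compound 1 `O=C1C(Nc2ccc(I)cc2)=CC(=O)c2c1nc1n2[C@H]2OC[C@@H](O)[C@H]2OC1`: 2530 nM in a functional assay on ECa-109 cells for inhibition, with ECa-109 cell line (Homo sapiens) as the target, read by sulforhodamine B assay; a higher number here means a weaker inhibitor, a lower number a stronger inhibitor
Compound 2 `CCc1ccc(NC2=CC(=O)c3nc4n(c3C2=O)[C@H]2OC[C@@H](O)[C@H]2OC4)cc1`: 3080 nM in this assay
Compound 3 `O=C1C(N2CCC2)=CC(=O)c2c1nc1n2[C@H]2OC[C@@H](O)[C@H]2OC1`: a limit of this assay, > 16000 nM

Compound 2 shows the higher of the two numbers in this assay; its nearest neighbour is compound 1, and the two lie within the scatter of each other. Compound 4 `O=C1C=C(N2CCCCC2)C(=O)c2c1nc1n2[C@H]2OC[C@@H](O)[C@H]2OC1` differs from compound 2 in one place: piperidin-1-yl in place of (4-ethylphenyl)amino on a double-bonded ring carbon. For the measured compounds named here, one measured step bears on this change, an at least 6.3-fold higher number from compound 1 to compound 3 (0.80 log units; beyond the scatter), in which a small saturated nitrogen ring replaced an arylamino group on the same carbon. That step ended at the limit of > 16000 nM in this assay, at which 1 of the 3 values shown sits. A step of at least comparable size toward a higher number is therefore expected for compound 4, with a fair chance that only a limit is reported; compound 4 is estimated at 18000 nM, ranging from 6000 nM to 50000 nM, an expected step of a 5.8-fold higher number from compound 2 to compound 4 (0.77 log units; beyond the scatter).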

Compound 4, half-maximal inhibitory concentration: > 8000 nM
Compound 4 was reported as a limit; the forecaster's own chance of this, stated with the estimate: 65%; the middle value lies beyond the limit too.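

In this assay, replacing an arylamino group with a saturated nitrogen ring on this double-bonded ring carbon again gives a weaker result, now with the larger piperidin-1-yl ring and a different arylamino starting point: an at least 2.5-fold higher number from compound 2 to compound 4 (0.41 log units; beyond the scatter). The loss is therefore not confined to azetidin-1-yl or to a single arylamino partner. Compound 4 is reported only as a limit, > 8000 nM, so this step sets a minimum and not a size.

The compounds shown do not separate the amine hydrogen from the aromatic ring. Cyclohexylamino would keep the hydrogen without the aromatic ring, whereas N-methyl-N-phenylamino would keep the aromatic ring without the hydrogen.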